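Swapping a chloro-bearing ring for a methyl-bearing one

This account rests on a few compounds, and the source may have more. Where it says the series, first, only, none or still open, it means among the compounds named here.

Of the compounds shown here, three sharing one core have been tested in a functional assay on A549 cells (Homo sapiens) for cytotoxicity, read by MTT assay, with a stated time of 24 h; on this read-out higher numbers stand for weaker inhibition and lower numbers for stronger inhibition. Compound 1 `c1ccc(CNC(c2ccc[nH]2)c2nnc(-c3ccccc3)o2)cc1` gives 187000 nM, compound 2 `Clc1cccc(-c2nnc(C(NCc3ccccc3)c3ccc[nH]3)o2)c1` gives 62200 nM, and compound 3 `Fc1cc(-c2nnc(C(NCc3ccccc3)c3ccc[nH]3)o2)c(Cl)cc1Cl` gives 27500 nM. Compound 2 therefore holds the second highest of the three numbers, sitting below compound 1 and above compound 3.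

Each measured step replaced the plain phenyl ring, or its chloro-bearing version, with a ring carrying more halogen: a 3.0-fold lower number from compound 1 to compound 2 (0.48 log units; beyond the scatter), a 6.8-fold lower number from compound 1 to compound 3 (0.83 log units; beyond the scatter) and a 2.3-fold lower number from compound 2 to compound 3 (0.35 log units; beyond the scatter). Every one of these lowered the number.

Compound 4 `Cc1ccc(-c2nnc(C(NCc3ccccc3)c3ccc[nH]3)o2)cc1` differs from compound 2 by 4-methylphenyl in place of 3-chlorophenyl on an aromatic carbon. Among the compounds with values here, no measured step tests a methyl on this ring, and the one halogen-free ring, in compound 1, gave the highest number. The step from compound 2 is expected to be a 1.5-fold higher number from compound 2 to compound 4 (0.18 log units; within the scatter), a modest rise, since the chloro that helped in compound 1 to compound 2 is gone. Compound 4 is estimated at 95000 nM, with a plausible range from 40000 nM to 220000 nM.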

Compound 4, half-maximal inhibitory concentration: 745000 nM
Estimate against measurement, compound 4: 7.8-fold (0.89 log units) below, outside the stated range (above it).
By their numbers in this assay, from the lowest: compound 3; then compound 2; then compound 1; then compound 4.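

In this assay, the methyl does more than fail to help: a 4.0-fold higher number from compound 1 to compound 4 (0.60 log units; beyond the scatter) shows that a group on this ring can raise the number above that of the plain phenyl ring, whereas every earlier change to the ring lowered it. Replacing a halogen-bearing ring gives much larger steps, with a 12-fold higher number from compound 2 to compound 4 (1.08 log units; beyond the scatter) and a 27-fold higher number from compound 3 to compound 4 (1.43 log units; beyond the scatter) setting the 4-methylphenyl ring well apart from both halogen-bearing rings. No measured evidence accounts for the opposite directions of the methyl and halogen changes.

The 3-chlorophenyl and 4-methylphenyl names differ in both the group and its ring position, so these compounds cannot separate the two effects. A 3-methylphenyl or 4-chlorophenyl ring would help to do so, while a ring bearing an amine or a carboxylic acid would show how far the range of this position extends.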